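A few compounds are considered here, and "the series" means these few. Any claim that something is new, unique, unknown or untested is made for them only; others in the source may bear on it.

Working notes on the series. The shared core is carried by compound 1 `CCCCNc1nc(C)nc2c1cnn2-c1ccccc1`, compound 2 `CCCNc1nc(CC)nc2c1cnn2-c1ccccc1`, compound 3 `CCc1nc(NC(C)C)c2cnn(-c3ccccc3)c2n1` and, still unmeasured, compound 4 `CCCCNc1nc(CC)nc2c1cnn2-c1ccccc1`. In a functional assay on G-361 cells (Homo sapiens) for cytotoxicity, read by sulforhodamine B assay (a higher number here means a weaker inhibitor of growth, a lower number a stronger inhibitor of growth), compound 2 gives 37000 nM. In this assay compound 1 reaches only the limit > 100000 nM. In this assay compound 3 likewise reaches only the limit > 100000 nM. Compound 3 thus stands at the weak end of the numbers shown; two of the three values shown are limits (the limit of > 100000 nM in this assay, at which 2 of the 3 values shown sit), and compound 2 alone yields a number.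

The change to compound 4 is butyl in place of isopropyl on a nitrogen on an aromatic ring. Going by the values given here, one measured step touches this nitrogen: an at least 2.7-fold higher number from compound 2 to compound 3 (0.43 log units; beyond the scatter). The change now made goes the other way, back to a straight chain, but the chain is one carbon longer than the propyl of compound 2. Compound 1, with the same butyl on this nitrogen and a methyl on the core in place of ethyl, sits at the limit. The return to a straight chain speaks for a lower number than compound 3, the added carbon and the standing of compound 1 against it, so only a modest move is expected, as an at least 1.6-fold lower number from compound 3 to compound 4 (0.22 log units; that floor lies within the scatter). Compound 4 is therefore expected to give 60000 nM, with a range of 25000 nM to 150000 nM.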

Compound 4, concentration for total growth inhibition: 32000 nM
Beside the measured number, compound 4's estimate is 1.9-fold (0.27 log units) above it; measured number inside the range.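

In this assay, the nitrogen tolerates a straight chain and not the isopropyl branch: butyl in place of isopropyl gives an at least 3.1-fold lower number from compound 3 to compound 4 (0.49 log units; beyond the scatter), while the two straight chains are not separated, with a 1.2-fold lower number from compound 2 to compound 4 (0.06 log units; within the scatter). The straight chain alone does not settle the outcome, as compound 1 also carries butyl on this nitrogen, and methyl in place of hydrogen on the saturated chain carbon bound to an aromatic carbon, which turns the methyl of compound 1 into the ethyl of compound 4, gives an at least 3.1-fold lower number from compound 1 to compound 4 (0.49 log units; beyond the scatter). Both steps beyond the scatter that end at compound 4 start from a limit, so they give only a floor for the size of each change: the limit of > 100000 nM in this assay, at which 2 of the 4 values shown sit.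

The compounds shown leave open whether a longer chain such as hexyl, or a hydroxyl at the end of the butyl, would carry the growth inhibition past the level shared by compound 2 and compound 4. They also leave open whether a propyl in place of the ethyl on the shared core would extend the gain seen with ethyl over methyl.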